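Adding 2-hydroxy-2-methylpropyl to compound 2

This account rests on a few compounds, and the source may have more. Where it says the series, first, only, none or still open, it means among the compounds named here.

In a functional assay on BT-474 cells (Homo sapiens) for inhibition, read by MTT assay, with a stated time of 5 days (a lower number here means a stronger inhibitor, a higher number a weaker inhibitor), compound 1 `Cc1cc(Nc2nc(NCc3ccc(F)cc3)nc3[nH]ncc23)n[nH]1` gives 8750 nM and compound 2 `Cc1cc(Nc2nc(NCc3ccc(Cl)cc3)nc3[nH]ncc23)n[nH]1` gives 11700 nM. These two values lie within the scatter of each other, so compound 2 stands level with compound 1. Compound 3 `Cc1cc(Nc2nc(NCc3ccc(Cl)cc3)nc3c2cnn3CC(C)(C)O)n[nH]1` carries 2-hydroxy-2-methylpropyl in place of hydrogen on an aromatic nitrogen. Among the compounds with values here, the only measured step, a 1.3-fold higher number from compound 1 to compound 2 (0.13 log units; within the scatter), is a chloro in place of fluoro on an aromatic carbon, so it offers no size for a change at this nitrogen. A modest move to a lower number in this assay is tentatively expected, with wide uncertainty in size and direction. The expected change is a 2.0-fold lower number from compound 2 to compound 3 (0.29 log units; within the scatter). For compound 3 the estimated value is 6000 nM, with an expected range of 1500 nM to 22000 nM.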

Compound 3, half-maximal inhibitory concentration: 16200 nM
For compound 3 the middle estimate is 2.7-fold (0.43 log units) below the measured one; the range from low to high includes it.
By their numbers in this assay, from the lowest: compounds 1, 2 and 3 (each within the scatter of the next).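

In this assay the replacement of hydrogen by 2-hydroxy-2-methylpropyl on the aromatic nitrogen amounts to a 1.4-fold higher number from compound 2 to compound 3 (0.14 log units; within the scatter) and stays within the scatter. This nitrogen therefore accepts this group with no measurable shift in the number, and the hydrogen there is not required to hold the value at this level. No supporting data bear on the reason for this outcome.

Open, from the compounds shown here alone, is whether a longer chain, an amine or a carboxylic acid at this nitrogen would also leave the number level. Also open, going by these compounds, is whether the same group gives a similar step on compound 1.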